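This account rests on a few compounds, and the source may have more. Where it says the series, first, only, none or still open, it means among the compounds named here.

Measured compounds:
Compound 1 `Cc1ccccc1NC(=S)N/N=C/c1ccc2ccccc2n1` gives > 100000 nM in a functional assay on SGC-7901 cells (Homo sapiens) for antiproliferative activity, read by sulforhodamine B assay, with a stated time of 72 h; on this read-out higher numbers stand for weaker inhibition and lower numbers for stronger inhibition; this is a limit of the assay, not a number.
Compound 2 `Cc1ccc(NC(=O)N/N=C/c2ccc3ccccc3n2)cc1` gives > 100000 nM in this assay; this too is a limit, not a number.
Compound 3 `CN(C)C(=S)N/N=C/c1cc2cccnc2s1` gives 21400 nM in this assay.

Compound 1 stands at the limit of this assay: its value is a limit, not a number, and it is one of two such values among the three shown, as recorded in the limit of > 100000 nM in this assay, at which 2 of the 3 values shown sit. Within the data shown here, compound 3 alone gives a measured number, and among the three it is the only compound with a value inside the measured range. Compound 4 `Fc1ccc(NC(=S)N/N=C/c2ccc3ccccc3n2)cc1` has not yet been measured in this assay. It differs from compound 1 in one place: 4-fluorophenyl in place of 2-methylphenyl on an amide-type nitrogen. Nothing else in the shared core changes. No step between two measured compounds is shown, so there is no measured guide to how much this change should move the value. With compound 1 sitting at a limit and compound 2 also at that limit, the expectation for compound 4 is a weak value, and the step from compound 1 to compound 4 that this estimate means, an at least 1.2-fold lower number from compound 1 to compound 4 (0.09 log units; that floor lies within the scatter), is expected to be within the usual scatter or not far beyond it. Compound 4 is therefore estimated at 80000 nM, in a range from 20000 nM to 300000 nM.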

Compound 4, half-maximal inhibitory concentration: 32300 nM
Compound 4: the middle estimate sits 2.5-fold (0.39 log units) above what was measured, within the range that was stated.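

In this assay compound 1 gives > 100000 nM, which is a limit of the assay and not a number. With 4-fluorophenyl in place of 2-methylphenyl on the amide-type nitrogen, the account gains its first step at this position, an at least 3.0-fold lower number from compound 1 to compound 4 (0.49 log units; beyond the scatter), showing that the group on this nitrogen can bring the shared core off the limit and into the measured range. The full size of the step cannot be read, because only one of its two ends is a number: the limit of > 100000 nM in this assay, at which 2 of the 4 values shown sit.

The compounds shown leave open whether the step comes from gaining the fluorine or from losing the methyl, and a plain phenyl, 2-fluorophenyl or 4-methylphenyl on this same nitrogen, with the thiocarbonyl kept, would help to separate the two. Also open, going by these compounds, is how the value would respond to a different kind of group at this place, such as 4-aminophenyl or 4-carboxyphenyl, and whether any such group would move the value further from that of compound 4, 32300 nM.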